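This account rests on a few compounds, and the source may have more. Where it says the series, first, only, none or still open, it means among the compounds named here.

Compound 1, `CC(=O)Nc1nc2ccc(-c3cnc(Cl)c(NS(=O)(=O)c4ccc(C)cc4)c3)cn2n1`, gives 3250 nM in a functional assay on MCF7 cells (Homo sapiens) for antiproliferative activity, read by MTT assay, with a stated time of 48 h; a lower number here means a stronger inhibitor, a higher number a weaker inhibitor.
Compound 2, `COc1ncc(-c2ccc3nc(NC(C)=O)nn3c2)cc1NS(=O)(=O)c1ccc(C)cc1`, gives 810 nM in this assay.
Compound 3, `COc1ncc(-c2ccc3nc(NC(=O)C4CC4)nn3c2)cc1NS(=O)(=O)c1ccc(F)cc1`, gives 2590 nM in this assay.

Compound 2 stands apart from compounds 1 and 3, while the values of compounds 1 and 3 lie within the scatter of each other. The difference between the cores of compound 2 and compound 3 is not broken down here. One structural change is measured once: from compound 2 to compound 1 it is chloro in place of methoxy on an aromatic carbon, and that step is a 4.0-fold higher number from compound 2 to compound 1 (0.60 log units; beyond the scatter).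

Compound 4, `O=C(Nc1nc2ccc(-c3cnc(Cl)c(NS(=O)(=O)c4ccc(F)cc4)c3)cn2n1)C1CC1`, has not yet been measured. It differs from compound 3 by chloro in place of methoxy on an aromatic carbon. In compound 1 the site is ortho to a large group, in compound 4 it is ortho to a ((4-fluorophenyl)sulfonyl)amino group, so this is the same kind of change rather than the same one. The expected step is a 3.1-fold higher number from compound 3 to compound 4 (0.49 log units; beyond the scatter), a little smaller than the measured one. Compound 4 is expected to give 8000 nM, likely between 3500 nM and 20000 nM, because the same kind of change gave a 4.0-fold higher number from compound 2 to compound 1 (0.60 log units; beyond the scatter).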

Compound 4, half-maximal inhibitory concentration: > 60000 nM
Compound 4 was reported as a limit; the forecaster's own chance of this, stated with the estimate: 10%; middle value at least 7.5-fold (0.87 log units) away from the limit.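

Chloro in place of methoxy gives a 4.0-fold higher number from compound 2 to compound 1 (0.60 log units; beyond the scatter), and on the second core it gives an at least 23-fold higher number from compound 3 to compound 4 (1.36 log units; beyond the scatter), so the direction of the change carries over between these two pairs. The size of the step does not carry over, since the two steps differ by more than the scatter: the same change on two cores in this assay, a 4.0-fold higher number (0.60 log units; beyond the scatter) from compound 2 to compound 1 and an at least 23-fold higher number (1.36 log units; beyond the scatter) from compound 3 to compound 4, at least 5.7-fold (0.76 log units) apart, beyond the scatter of two such steps

The value of compound 4, > 60000 nM, is a limit and not a number, and these two pairs alone do not show why the steps differ or how the change would behave on any further core.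

As far as these compounds go, the cores of the two pairs differ in both the amide and the substituent on the sulfonyl-bearing phenyl ring, and it remains open which of these goes with the larger step. From the compounds shown here alone, how other groups at this site, such as bromo, ethoxy or an amine, would fall in this assay also remains open.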